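The source may hold more compounds than are shown below. What is called first, only, known or untested is meant among the compounds shown, and "the series" means these compounds.

Series notes. Compound 1 `Cc1ccccc1C(=O)Nc1ccc(S(=O)(=O)NC2CCN(C(=O)C3CCCC3)CC2)c2ccccc12` gives 9.1 nM in an assay on L1.2 cells for binding affinity to C-C chemokine receptor type 8 (Homo sapiens); on this read-out higher numbers stand for weaker inhibition and lower numbers for stronger inhibition; compound 2 `Cc1ccccc1C(=O)Nc1ccc(S(=O)(=O)NC2CCN(C(=O)CN)CC2)c2ccccc12` gives 4.1 nM; compound 3 `CNC(=O)N1CCC(NS(=O)(=O)c2ccc(NC(=O)c3ccccc3C)c3ccccc23)CC1` gives 0.7 nM. Compound 3 stands lowest of the three measured numbers: the steps of a 13-fold lower number from compound 1 to compound 3 (1.11 log units; beyond the scatter) and a 5.9-fold lower number from compound 2 to compound 3 (0.77 log units; beyond the scatter) both lie beyond the scatter, as does a 2.2-fold lower number from compound 1 to compound 2 (0.35 log units; beyond the scatter). Compound 4 `Cc1ccccc1C(=O)Nc1ccc(S(=O)(=O)NC2CCN(C(=O)N3CCC3)CC2)c2ccccc12` differs from compound 3 by azetidin-1-yl in place of methylamino on a carbonyl carbon. Among the measured compounds shown here, no measured step exchanges methylamino for a ring on that carbonyl; every measured step leads toward the methylamino and toward the lowest number, and the only step not involving compound 3, a 2.2-fold lower number from compound 1 to compound 2 (0.35 log units; beyond the scatter), is modest. The exchange in compound 4 keeps a nitrogen on the carbonyl carbon, as in compound 3, but gives up the one hydrogen-bond donor counted there. A modest move toward a higher number in this assay is therefore expected, not a large one, and possibly within the scatter. Compound 4 is expected to give 2 nM with a range from 0.7 nM to 6 nM. The estimated step of a 2.9-fold higher number from compound 3 to compound 4 (0.46 log units; beyond the scatter) is expected to remain modest.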

Compound 4, inhibition constant: 3.5 nM
The estimate for compound 4 lay 1.8-fold (0.24 log units) below the measured number, within the range that was stated.
By their numbers in this assay, from the lowest: compound 3; then compounds 4 and 2 (each within the scatter of the next); then compound 1.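

In this assay, the exchange a 5.0-fold higher number from compound 3 to compound 4 (0.70 log units; beyond the scatter) lies beyond the scatter, so keeping a nitrogen on the carbonyl carbon does not by itself retain the number of compound 3 when methylamino, with its hydrogen-bond donor, gives way to azetidin-1-yl with none. The step of a 1.2-fold lower number from compound 2 to compound 4 (0.07 log units; within the scatter) lies within the scatter, so azetidin-1-yl and aminomethyl cannot be ordered here, while the step of a 2.6-fold lower number from compound 1 to compound 4 (0.41 log units; beyond the scatter) shows that the two rings on this carbonyl carbon, azetidin-1-yl and cyclopentyl, do not give the same number. No measurement bears on the reason for these differences.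

The change from compound 3 to compound 4 alters the donor count and adds a ring at once, leaving those two differences unseparated. Dimethylamino, with no ring or donor, and ethylamino, with a donor and a longer chain, remain open at this position.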